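Ethynyl for Thiophene on a Shared Nucleoside Core

A few compounds are considered here, and "the series" means these few. Any claim that something is new, unique, unknown or untested is made for them only; others in the source may bear on it.

Compound 1 `C#Cc1cn([C@@H]2O[C@H](CO)[C@@H](O)[C@H]2O)c2ncnc(C)c12` gives > 20000 nM in a functional assay on HCT-116 cells (Homo sapiens), read by MTT assay, with a stated time of 72 h (a higher number here means a weaker inhibitor, a lower number a stronger inhibitor), which is a limit of the assay and not a number.
Compound 2 `COc1nc(N)nc2c1c(-c1cccs1)cn2[C@@H]1O[C@H](CO)[C@@H](O)[C@H]1O` gives > 20000 nM in this assay, again a limit rather than a number.
Compound 3 `Cc1ncnc2c1c(-c1cccs1)cn2[C@@H]1O[C@H](CO)[C@@H](O)[C@H]1O` gives > 20000 nM in this assay, also a limit.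

All three measured values sit at the limit of > 20000 nM in this assay, at which 3 of the 3 values shown sit. Because of that, the change from compound 3 to compound 1, namely (ethynyl in place of thiophen-2-yl on an aromatic carbon), leaves a step that cannot be read: a step that the two limits leave unreadable from compound 3 to compound 1.

Compound 4 `C#Cc1cn([C@@H]2O[C@H](CO)[C@@H](O)[C@H]2O)c2nc(N)nc(OC)c12` is not yet measured. It differs from compound 2 by ethynyl in place of thiophen-2-yl on an aromatic carbon. The two "place" descriptions match word for word, so this is the same change as that made between compound 3 and compound 1. How the core of compound 2 differs from that of compound 3 is not broken down here.

For the measured compounds named here, the step from compound 2 to compound 4 is expected to be a step that the limit leaves unreadable from compound 2 to compound 4, since the only measured example of this change, a step that the two limits leave unreadable from compound 3 to compound 1, shows no readable movement. For compound 4 the estimated value in this assay is 30000 nM, most likely reported only as a limit again.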

Compound 4, half-maximal inhibitory concentration: > 20000 nM
Compound 4: only a limit was reported; the forecaster's own chance of this, stated with the estimate: 85%; the middle value does not contradict the limit.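

In this assay compound 4 gives > 20000 nM, which is a limit and not a number. The step from compound 2 to compound 4 therefore cannot be read, since the values all stop at one limit: the limit of > 20000 nM in this assay, at which 4 of the 4 values shown sit. The compounds shown leave open whether ethynyl and thiophen-2-yl differ at all in this assay on either core.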